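The compounds below may be only part of what the source reports. "The series", "measured", "known", "first", "only" and "open" are said of these compounds alone.

Measured so far in a functional assay on the whole organism for antagonist activity, with Mus musculus as the target; on this read-out higher numbers stand for an effect only at larger amounts of compound and lower numbers for an effect already at smaller amounts:
Compound 1 `COc1cc(N)c(Cl)cc1NC(=O)C1CCN(CC2CCCCC2)CC1` gives 2.9 mg/kg.
Compound 2 `COc1cc(N)c(Cl)cc1NC(=O)C1CCN(Cc2ccc(Cl)cc2)CC1` gives 1.2 mg/kg.
Compound 3 `COc1cc(N)c(Cl)cc1NC(=O)C1CCN(Cc2ccccc2Cl)CC1` gives only a limit of the assay, > 4 mg/kg.

Among the two numbers, compound 1 stands highest; its nearest neighbour is compound 2, with a 2.4-fold lower number from compound 1 to compound 2 (0.38 log units; beyond the scatter). Compound 4 `COc1cc(N)c(Cl)cc1NC(=O)C1CCN(CC2CCCCCC2)CC1` differs from compound 1 by cycloheptyl in place of cyclohexyl on a saturated chain carbon bound to an amine nitrogen in a ring. Neither of the measured steps that start from compound 1 enlarges the saturated ring; both swap the cyclohexyl for a chlorophenyl, so they give no direct guide to this change. Adding one carbon to the ring is therefore expected to shift the dose for half-maximal effect by no more than the usual scatter, as a 1.0-fold higher number from compound 1 to compound 4 (0.01 log units; within the scatter). Compound 4 is thus estimated at 3 mg/kg, within a range from 1.5 mg/kg to 6 mg/kg.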

Compound 4, dose for half-maximal effect: > 10 mg/kg
Compound 4: a limit, no number; the forecaster's own chance of this, stated with the estimate: 25%; at least 3.3-fold (0.52 log units) between middle value and limit.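

In this assay, this position proves sensitive to ring size: cycloheptyl in place of cyclohexyl gives an at least 3.4-fold higher number from compound 1 to compound 4 (0.53 log units; beyond the scatter), so a single added ring carbon is enough to move the result beyond the scatter. Set against the 4-chlorophenyl group, the same cycloheptyl gives an at least 8.3-fold higher number from compound 2 to compound 4 (0.92 log units; beyond the scatter). Compound 4 gives only a limit of the assay, and the step between compound 3 and compound 4 cannot be read: the limit of > 10 mg/kg in this assay, at which 1 of the 4 values shown sits.

As far as these compounds go, whether the smaller cyclopentyl ring, or an open hexyl chain in place of the ring, would stay close to compound 1 remains open.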